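Methyl Removal on an Aryl Oxygen in a Urea Series

The source may report more compounds than this note shows. Statements on the series, on what has been measured and on what is new or still open speak of the compounds shown alone.

Measured compounds:
compound 1, `COc1cc(-c2nn(-c3cccc(NC(=O)Nc4cc(C(F)(F)F)cc(C(F)(F)F)c4)c3)cc2-c2ccncc2)ccc1Cl`, gives 307 nM
compound 2, `O=C(Nc1cccc(-n2cc(-c3ccncc3)c(-c3ccc(Cl)c(O)c3)n2)c1)Nc1cc(C(F)(F)F)cc(C(F)(F)F)c1`, gives 265 nM
compound 3, `COc1cc(-c2nn(-c3cccc(NC(=O)Nc4ccc(Cl)c(C(F)(F)F)c4)c3)cc2-c2ccncc2)ccc1Cl`, gives 833 nM

Three compounds were tested in a functional assay on MDA-MB-468 cells (Homo sapiens) for inhibition, read by sulforhodamine B assay, with a stated time of 48 h; on this read-out higher numbers stand for weaker inhibition of growth and lower numbers for stronger inhibition of growth. Compound 1 and compound 2 share a core and differ by one change, (hydrogen in place of methyl on an oxygen on an aromatic ring), which produced a 1.2-fold lower number from compound 1 to compound 2 (0.06 log units; within the scatter). The two values therefore sit together and no order between them is claimed. Compound 3 gives the highest number of the three, with compound 1 nearest and compound 2 furthest, both gaps lying beyond the scatter. The difference between the core of compound 3 and the core of compound 1 is not broken down here.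

Compound 4, `O=C(Nc1cccc(-n2cc(-c3ccncc3)c(-c3ccc(Cl)c(O)c3)n2)c1)Nc1ccc(Cl)c(C(F)(F)F)c1`, has not yet been measured in this assay . It stands to compound 3 as compound 2 stands to compound 1: the change is hydrogen in place of methyl on an oxygen on an aromatic ring, and its place line matches that of the earlier pair word for word, so it is the same change. For the measured compounds named here, since the one measured instance of this change, a 1.2-fold lower number from compound 1 to compound 2 (0.06 log units; within the scatter), stayed within the scatter, compound 4 is expected to land near compound 3, an estimated step of a 1.2-fold lower number from compound 3 to compound 4 (0.08 log units; within the scatter). This expectation rests on a single pair and on compound 3 giving 833 nM. The estimate for compound 4 in this assay is 700 nM, with a likely range from 350 nM to 1400 nM.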

Compound 4, concentration for 50% growth inhibition: 541 nM
For compound 4 the middle estimate is 1.3-fold (0.11 log units) above the measured one; low and high end bracket the measured number.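

In this assay, going from methoxy to hydroxy on the 4-chloro-3-methoxyphenyl group gave a 1.5-fold lower number from compound 3 to compound 4 (0.19 log units; within the scatter), so these two values sit together and no order between them is claimed. Set beside the earlier pair, the same change reads alike on the two cores: the same change on two cores in this assay, a 1.2-fold lower number (0.06 log units; within the scatter) from compound 1 to compound 2 and a 1.5-fold lower number (0.19 log units; within the scatter) from compound 3 to compound 4, 1.3-fold (0.12 log units) apart, within the scatter of two such steps. Within this series, then, the small step seen on the first core carried over to the second, but this rests on two pairs in a single assay and does not show that the step would stay as small on any further core, nor does it explain what lies behind the result.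

The compounds shown leave open how an ethyl group or a longer chain on that oxygen would read, and likewise an amine in place of the hydroxy. Also open, going by these compounds, is whether the step would stay the same without the chloro of the 4-chloro-3-hydroxyphenyl group, as the chloro is present in both the methoxy and hydroxy forms of all four compounds.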